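A few compounds are considered here, and "the series" means these few. Any claim that something is new, unique, unknown or untested is made for them only; others in the source may bear on it.

In a functional assay on HepG2 cells (Homo sapiens) for cytotoxicity, read by MTT assay, with a stated time of 24 h (on this read-out higher numbers stand for weaker inhibition and lower numbers for stronger inhibition), compound 2 `O=C1/C(=C/c2ccncc2)CNC/C1=C\c1ccccc1C(F)(F)F` gives 6130 nM and compound 3 `O=C1/C(=C/c2ccncc2)CN(S(=O)(=O)c2ccccc2)C/C1=C\c1ccccc1C(F)(F)F` gives 7020 nM while compound 1 `Cc1ccc(S(=O)(=O)N2C/C(=C\c3ccncc3)C(=O)/C(=C/c3ccccc3F)C2)cc1` gives 9700 nM and so compound 3 stands within the scatter of both. Compound 4 `Cc1ccc(S(=O)(=O)N2C/C(=C\c3ccncc3)C(=O)/C(=C/c3ccccc3C(F)(F)F)C2)cc1` differs from compound 3 by one change (methyl in place of hydrogen on an aromatic carbon) in which methyl replaces hydrogen on an aromatic carbon, so phenylsulfonyl becomes (4-methylphenyl)sulfonyl. The nearest measured evidence is a 1.1-fold higher number from compound 2 to compound 3 (0.06 log units; within the scatter) for adding the whole phenylsulfonyl group on the ring nitrogen. With fluorine where compound 3 has trifluoromethyl, compound 1 already carries (4-methylphenyl)sulfonyl and gives 9700 nM within the scatter of compound 3. No step beyond the scatter is therefore expected, and the estimated change (a 1.1-fold higher number from compound 3 to compound 4 (0.03 log units; within the scatter)) is small. The expected value for compound 4 is 7500 nM in this assay (estimated range 4500 nM to 12500 nM).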

Compound 4, half-maximal inhibitory concentration: 4640 nM
The estimate for compound 4 lay 1.6-fold (0.21 log units) above the measured number; the range from low to high includes it.
By their numbers in this assay, from the lowest: compounds 4, 2, 3 and 1 (each within the scatter of the next, the first and the last beyond it).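

In this assay, methyl on the aromatic carbon para to a large group gives a 1.5-fold lower number from compound 3 to compound 4 (0.18 log units; within the scatter), so this position takes a methyl without a step beyond the scatter. Going by these compounds alone, the whole (4-methylphenyl)sulfonyl group in place of hydrogen on the ring nitrogen gives a 1.3-fold lower number from compound 2 to compound 4 (0.12 log units; within the scatter), while trifluoromethyl in place of fluoro, with that sulfonyl group kept, gives a 2.1-fold lower number from compound 1 to compound 4 (0.32 log units; beyond the scatter), the only one of these three steps beyond the scatter, and a modest one. Nothing available here explains these steps. As far as these compounds go, how a methoxy group, an amine or a carboxylic acid on this same aromatic carbon would read remains open.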